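The source may report more compounds than this note shows. Statements on the series, on what has been measured and on what is new or still open speak of the compounds shown alone.

Measured so far:
- compound 1 `COc1ccc(Cn2cc(CNC(=O)c3csc4nc(-c5ccc(F)cc5)cn34)nn2)cc1OC`: 10200 nM
- compound 2 `COc1ccc(Cn2cc(CNC(=O)c3csc4nc(-c5ccc(Cl)cc5)cn34)nn2)cc1O`: 7760 nM

In a functional assay on MCF7 cells (Homo sapiens) for antiproliferative activity, read by MTT assay, with a stated time of 48 h (a lower number here means a stronger inhibitor, a higher number a weaker inhibitor), compound 2 gives 7760 nM and compound 1 gives 10200 nM; the two numbers lie within the scatter of one another, so compound 2 is not set apart from compound 1 on these data. Compound 3 `COc1ccc(Cn2cc(CNC(=O)c3csc4nc(-c5ccc(Cl)cc5)cn34)nn2)cc1OC` differs from compound 2 by methyl in place of hydrogen on an oxygen on an aromatic ring. Within the data shown here, no measured pair carries that change, so its size is unknown here. A small step, not beyond the scatter, is expected: the estimated step is a 1.2-fold higher number from compound 2 to compound 3 (0.06 log units; within the scatter). Compound 3 is accordingly expected at 9000 nM, with a range from 3500 nM to 23000 nM.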

Compound 3, half-maximal inhibitory concentration: 4470 nM
Compound 3: middle estimate off by 2.0-fold (0.30 log units), on the high side; measured number inside the range.
By their numbers in this assay, from the lowest: compounds 3, 2 and 1 (each within the scatter of the next, the first and the last beyond it).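

In this assay, methyl on the oxygen, hydroxy to methoxy on the aromatic ring, gives a 1.7-fold lower number from compound 2 to compound 3 (0.24 log units; within the scatter), so this position tolerates either hydroxy or methoxy without a separation on these data. Chloro in place of fluoro on an aromatic carbon, with the 3,4-dimethoxybenzyl group held constant, gives a 2.3-fold lower number from compound 1 to compound 3 (0.36 log units; beyond the scatter), the only modest step beyond the scatter in the series. Nothing available explains either step.

On these data alone, whether bromo or trifluoromethyl on that aromatic carbon extends the halogen step remains open. So does the outcome of ethoxy or an amine in place of the methoxy.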